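The compounds below may be only part of what the source reports. "The series", "measured", "known", "first", "only" and "open" are said of these compounds alone.

The series shares the core of compound 1 `CN(C)c1cc2[nH]c(C3CCCCC3)nc2cc1NC(=O)OCC(F)(F)F`. In an ADME assay on Vero cells (Chlorocebus sabaeus) for cytotoxicity, read by resazurin assay, with a stated time of 3 days (a lower number here means a stronger inhibitor, a higher number a weaker inhibitor), compound 1 reaches only a limit, > 100 ug/mL, and the assay gives no number for it. Compound 2 `CCCOCC(=O)Nc1cc2nc(C3CCCCC3)[nH]c2cc1N(C)C` carries propoxymethyl in place of 2,2,2-trifluoroethoxy on a carbonyl carbon. In this assay compound 2 likewise sits at a limit, < 50 ug/mL. From the compounds shown here alone, the step of an at least 2.0-fold lower number from compound 1 to compound 2 (0.30 log units; that floor lies within the scatter) is therefore framed by two limits, one at the limit of > 100 ug/mL in this assay, at which 1 of the 2 values shown sits, and one at the limit of < 50 ug/mL in this assay, at which 1 of the 2 values shown sits, so its true size stays open. Compound 3 `O=C(Nc1cc2nc(C3CCCCC3)[nH]c2cc1N1CCCC1)OCC(F)(F)F` differs from compound 1 in another place: pyrrolidin-1-yl in place of dimethylamino on an aromatic carbon. For the measured compounds named here, no measured step touches this exchange on the aromatic carbon; the only known step changes the group on the carbonyl carbon instead. Compound 1 itself stands at a limit and not at a number. With nothing pointing in either direction, compound 3 is expected to show no step beyond the scatter, an estimated a number no higher from compound 1 to compound 3 (the limit leaves the size open). Compound 3 is thus estimated at 100 ug/mL, within 50 ug/mL to 200 ug/mL, and is likely to be reported again only as a limit.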

Compound 3, half-maximal inhibitory concentration: > 100 ug/mL
Compound 3 was reported as a limit (the forecaster's own chance of this, stated with the estimate: 70%); the middle value lies on the limit itself.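

In this assay compound 3 gives > 100 ug/mL, which is a limit and not a number. Compound 1 also stands at a limit, so the step between compound 1 and compound 3 cannot be read. The compounds shown leave open what pyrrolidin-1-yl in place of dimethylamino on an aromatic carbon does to the true value in this assay.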